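Compound 3 to compound 4: phenyl for hydroxymethyl

A few compounds are considered here, and "the series" means these few. Any claim that something is new, unique, unknown or untested is made for them only; others in the source may bear on it.

Compound 1, `O=C1c2ccccc2NS(=O)(=O)N1COCCO`: 160 ug/mL in a functional assay on HEL cells (Homo sapiens); a higher number here means that more compound is tolerated, a lower number that less compound is tolerated
Compound 2, `CCCOCN1c2ccccc2C(=O)NS1(=O)=O`: in this assay only a limit, > 50 ug/mL
Compound 3, `O=C1NS(=O)(=O)N(COCCO)c2ccccc21`: 112 ug/mL in this assay

Compound 3 holds the lowest of the two numbers in this assay; compound 1 is nearest, and the gap between them lies within the scatter. The step that the limit leaves unreadable from compound 2 to compound 3 cannot be read because of the limit of > 50 ug/mL in this assay, at which 1 of the 3 values shown sits. Compound 4, `O=C1NS(=O)(=O)N(COCc2ccccc2)c2ccccc21`, differs from compound 3 in one place: phenyl in place of hydroxymethyl on a saturated chain carbon bound to an oxygen on a saturated carbon. For the measured compounds named here, no measured step bears readably on this change, so no step beyond the scatter is expected in this assay in either direction. Compound 4 is therefore expected to give 90 ug/mL in this assay, between 35 ug/mL and 220 ug/mL. The expected step is a 1.2-fold lower number from compound 3 to compound 4 (0.09 log units; within the scatter).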

Compound 4, half-maximal cytotoxic concentration: > 50 ug/mL
Compound 4: a limit, no number; the forecaster's own chance of this, stated with the estimate: 30%; the middle value is on the limit's open side.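

Neither the step from compound 3 to compound 4 nor the one from compound 2 to compound 4 can be read in this assay: the limit of > 50 ug/mL in this assay, at which 2 of the 4 values shown sit.

As far as these compounds go, whether benzyl in place of 2-hydroxyethyl shifts the tolerated concentration in either direction stays open.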